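Trimming a Heptyloxy Chain to a Branched Cyclopropylmethyl Ether

This account rests on a few compounds, and the source may have more. Where it says the series, first, only, none or still open, it means among the compounds named here.

Compound 3 `CCCCCCCOc1cc(CCc2nc(C)c(CC)s2)nc(NCc2cc(Cl)cc(NC(=O)OC(C)C)c2)c1` gives 72 nM in an assay on cells for binding affinity to Neuropeptide Y receptor type 1 (Homo sapiens) (on this read-out higher numbers stand for weaker inhibition and lower numbers for stronger inhibition), and stands second highest of the three numbers. Compound 2 `CCCCCOc1cc(CCc2nc(C)c(CC)s2)nc(NCc2cc(Cl)cc(NC(=O)OC(C)C)c2)c1` gives 35 nM, while compound 1 `CCc1sc(CCc2cc(OC)cc(NCc3cc(Cl)cc(NC(=O)OC(C)C)c3)n2)nc1C` gives 234 nM. The measured steps in this assay were a 6.7-fold lower number from compound 1 to compound 2 (0.83 log units; beyond the scatter) and a 3.3-fold lower number from compound 1 to compound 3 (0.51 log units; beyond the scatter), with further lengthening giving a 2.1-fold higher number from compound 2 to compound 3 (0.31 log units; beyond the scatter). Compound 4 `CCc1sc(CCc2cc(OCC3(C)CC3)cc(NCc3cc(Cl)cc(NC(=O)OC(C)C)c3)n2)nc1C` carries 1-methylcyclopropyl in place of hexyl on a saturated chain carbon bound to an oxygen on an aromatic ring. Among the measured compounds shown here, the steps that bear on it show a modest gain on building out from hydrogen and a smaller loss on going longer still; a shorter, branched group lies between those cases, so only a small step, probably within the scatter, is expected in this assay. Compound 4 is therefore expected to give 60 nM, with a range from 25 nM to 150 nM, which is expected to mean a 1.2-fold lower number from compound 3 to compound 4 (0.08 log units; within the scatter).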

Compound 4, half-maximal inhibitory concentration: 17 nM
For compound 4 the middle estimate is 3.5-fold (0.55 log units) above the measured one; the measured number lies below the stated range.
By their numbers in this assay, from the lowest: compound 4; then compound 2; then compound 3; then compound 1.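

In this assay the (1-methylcyclopropyl)methoxy group gives a 4.2-fold lower number from compound 3 to compound 4 (0.63 log units; beyond the scatter) and a 2.1-fold lower number from compound 2 to compound 4 (0.31 log units; beyond the scatter) and so goes past both longer straight chains at this position, which lengthening the chain alone had not done. Among the compounds shown here, measured against the methoxy group, the change reaches a 14-fold lower number from compound 1 to compound 4 (1.14 log units; beyond the scatter) and is the only large step here. No measurement shown gives a reason for this gain. Going by these compounds, whether the methyl on the ring is needed, and whether a cyclobutyl ring or an amine at this place would do as well, stays open.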